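Acylsemicarbazone variants on a shared core against prostate cancer cells

A few compounds are considered here, and "the series" means these few. Any claim that something is new, unique, unknown or untested is made for them only; others in the source may bear on it.

Measured compounds:
compound 1 `O=C(N/N=C/c1cccc(Br)c1)Nc1ccc(Oc2ccnc3[nH]ccc23)c(F)c1`, 4020 nM
compound 2 `COc1ccc(/C=N/NC(=O)Nc2ccc(Oc3ccnc4[nH]ccc34)c(F)c2)cc1`, 6730 nM

Two compounds share a core and differ only in the aryl group on a carbon with a double bond to nitrogen. In a functional assay on PC-3 cells (Homo sapiens) for antiproliferative activity, read by MTT assay, with a stated time of 72 h (a higher number here means a weaker inhibitor, a lower number a stronger inhibitor), compound 1 gives 4020 nM, the lowest of the two numbers, and compound 2 gives 6730 nM; the step of a 1.7-fold higher number from compound 1 to compound 2 (0.22 log units; within the scatter) lies within the scatter.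

Compound 3 `O=C(N/N=C/c1cc(Br)c(O)c(Br)c1)Nc1ccc(Oc2ccnc3[nH]ccc23)c(F)c1` is not yet measured. Its change from compound 1 is 3,5-dibromo-4-hydroxyphenyl in place of 3-bromophenyl on a carbon with a double bond to nitrogen. Within the data shown here, the only measured step that bears on it is the exchange of the same aryl group from compound 1 to compound 2, which was within the scatter. Among the measured compounds shown here, no measured step touches a hydroxyl or a second bromine on this ring. Compound 3 is therefore expected to stay near compound 1, with a step of a 1.1-fold lower number from compound 1 to compound 3 (0.06 log units; within the scatter) in this assay that need not exceed the scatter. The estimate for compound 3 is 3500 nM, in a range from 1200 nM to 10000 nM.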

Compound 3, half-maximal inhibitory concentration: "not active" (no number reported)
The entry for compound 3 holds no number, so the estimate cannot be set against anything.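

In this assay, among these compounds, compound 3 is reported as "not active" with no number, so no step from compound 1 can be read. The compounds shown leave open whether the hydroxyl or the second bromine of the 3,5-dibromo-4-hydroxyphenyl group goes with this result. No measurement given here offers an explanation for it.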